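Working notes: from compound 3 to compound 4

The compounds below may be only part of what the source reports. "The series", "measured", "known", "first", "only" and "open" are said of these compounds alone.

Measured so far in a functional assay on the whole organism (strain albino) for inhibition, with Rattus norvegicus as the target, read by paw edema, with a stated time of 1 h, at a dose of 20 mmol/kg by the intraperitoneal route; on this read-out higher numbers stand for more inhibition at the one dose given (going by the name of the read-out) and lower numbers for less inhibition:
compound 1 `N#CC1=C(NCC(=O)O)N(c2ccccc2)C(=O)N2CCCCC(N3CCCC3)C12` gives 67.2%
compound 2 `N#CC1=C(NCN2CCCCC2)N(c2ccccc2)C(=O)N2CCCCC(N3CCCC3)C12` gives 29.7%
compound 3 `CCOC(=O)C(=O)NC1=C(C#N)C2C(N3CCCC3)CCCCN2C(=O)N1c1ccccc1` gives 71.2%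

Compound 3 stands at the top of the three numbers in this assay, yet its lead over compound 1 is only a number 4 percentage points higher from compound 1 to compound 3 (within the scatter), which is within the scatter, while the other step up to it is a number 41.5 percentage points higher from compound 2 to compound 3 (beyond the scatter). Compound 4 `COc1ccc(/C=N/C2=C(C#N)C3C(N4CCCC4)CCCCN3C(=O)N2c2ccccc2)cc1` is the next member to be measured. The change is a group of 10 heavy atoms (8 carbon, 1 nitrogen, 1 oxygen; one six-membered aromatic ring of carbon only) in place of a group of 8 heavy atoms (4 carbon, 1 nitrogen, 3 oxygen; no ring), on a double-bonded ring carbon.

Within the data shown here, two measured steps touch the same place. Replacing the carboxymethyl group of compound 1 by the (ethoxycarbonyl)carbonyl group changed little, a number 4 percentage points higher from compound 1 to compound 3 (within the scatter). Replacing carboxy by piperidin-1-yl cost much, a number 37.5 percentage points lower from compound 1 to compound 2 (beyond the scatter). Both groups that scored well carry a hydrogen-bond donor and carbonyl oxygens; the entering group in compound 4 has none of the former and only an aromatic ring and an imine double bond. Among the measured compounds shown here, no measured step tells how such a group fares, so the expectation is uncertain and leans toward a drop.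

In this assay compound 4 is expected to give about 50%, between 25% and 75%. This would be an expected step of a number 21.2 percentage points lower from compound 3 to compound 4 (beyond the scatter).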

Compound 4, a percentage reported as inhibition, in the whole organism at one dose (the size of the read-out at that dose, not a potency): 59.1%
Beside the measured number, compound 4's estimate is 9.1 percentage points below it; measured number inside the range.
By their numbers in this assay, from the lowest: compound 2; then compounds 4, 1 and 3 (each within the scatter of the next, the first and the last beyond it).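

The double-bonded ring carbon accepts a group with a six-membered aromatic ring of carbon only and 0 hydrogen-bond donors without falling to the level of compound 2, with a number 29.4 percentage points higher from compound 2 to compound 4 (beyond the scatter). Against the two higher-scoring groups the result splits, with a number 12.1 percentage points lower from compound 3 to compound 4 (beyond the scatter) but a number 8.1 percentage points lower from compound 1 to compound 4 (within the scatter), so a hydrogen-bond donor in the group on this carbon is not needed to stay within the scatter of compound 1, though the new group stays short of compound 3. Nothing measured here accounts for these steps.

The compounds shown do not separate the share of the methoxy group from that of the aromatic ring or the imine link, which an unsubstituted benzylidene imine or a chloro-substituted one would address. Also open, from the compounds shown here alone, is how a longer chain ending in a carboxylic acid would fare on this carbon.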